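Ring methyl removed from compound 3

The source may report more compounds than this note shows. Statements on the series, on what has been measured and on what is new or still open speak of the compounds shown alone.

Three compounds of this series have numbers in an assay on membranes from brain for binding affinity to Monoglyceride lipase (Mus musculus), read by fluorescence, with stated times of 1 h and 30 min; a lower number here means a stronger inhibitor, a higher number a weaker inhibitor. Compound 1 `Cc1cnn(C(=O)N(C)CCN(C)Cc2ccc(OCc3ccccc3)cc2)c1` gives 1200 nM. Compound 2 `CN(CCN(C)C(=O)n1cc(C#N)cn1)Cc1ccc(OCc2ccccc2)cc1` gives 260 nM. Compound 3 `Cc1cnn(C(=O)N(C)CCN(C)Cc2cccc(OCc3ccccc3)c2)c1` gives 4100 nM, the highest of the three numbers; its nearest neighbour is compound 1, and compound 2 lies furthest from it. The only single-point step among these, a 4.6-fold lower number from compound 1 to compound 2 (0.66 log units; beyond the scatter), concerns a cyano group replacing the methyl on the five-membered aromatic ring with two nitrogen.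

Compound 4 `CN(CCN(C)C(=O)n1cccn1)Cc1cccc(OCc2ccccc2)c1` differs from compound 3 by hydrogen in place of methyl on an aromatic carbon. Among the measured compounds shown here, no measured pair shows this exact change; the step from compound 1 to compound 2 removes a methyl from the same kind of aromatic carbon but puts cyano in its place rather than hydrogen, so it speaks to the site of the change and not to its direction. With nothing closer to lean on, the step from compound 3 to compound 4 is expected to stay within the scatter, a 1.2-fold higher number from compound 3 to compound 4 (0.09 log units; within the scatter), with the range allowing a somewhat higher number. Compound 4 is accordingly estimated at 5000 nM in this assay, within 2000 nM to 12000 nM.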

Compound 4, half-maximal inhibitory concentration: 4600 nM
The estimate for compound 4 lay 1.1-fold (0.04 log units) above the measured number; low and high end bracket the measured number.
By their numbers in this assay, from the lowest: compound 2; then compound 1; then compounds 3 and 4 (each within the scatter of the next).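

In this assay, a 1.1-fold higher number from compound 3 to compound 4 (0.05 log units; within the scatter) stays within the scatter, so the methyl on this aromatic carbon of the five-membered aromatic ring with 2 nitrogen can be taken off, going from 4-methyl-1H-pyrazol-1-yl to 1H-pyrazol-1-yl, without a readable change in the number. The same carbon is nevertheless not indifferent to what it carries, since a 4.6-fold lower number from compound 1 to compound 2 (0.66 log units; beyond the scatter) in the same assay lies beyond the scatter, and the site therefore responds to cyano in place of methyl but gives no readable response to hydrogen in place of methyl, with each step seen on its own core. Nothing at hand gives a reason for the flat step from methyl to hydrogen.

Still open, on these data alone, is whether hydrogen in place of methyl would be just as flat on the core of compound 1, where the cyano step was read, and whether cyano would give on the core of compound 3 the step it gave on the core of compound 1. Also open, as far as these compounds go, is how this carbon would respond to other groups, such as chlorine, an amide or a carboxylic acid, and whether any of them would follow cyano or follow hydrogen.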